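Chloro for Methoxy on the Sulfonyl Aryl Ring

A few compounds are considered here, and "the series" means these few. Any claim that something is new, unique, unknown or untested is made for them only; others in the source may bear on it.

Compound 1 `CC1CCN(c2c(S(=O)(=O)c3cccc(F)c3)cnc3ccc(F)cc23)CC1`: 76%
Compound 2 `CC1CCN(c2c(S(=O)(=O)c3cccc(C#N)c3)cnc3ccc(F)cc23)CC1`: 93%
Compound 3 `COc1ccc(S(=O)(=O)c2cnc3ccc(F)cc3c2N2CCC(C)CC2)cc1Cl`: 82%

Of the compounds shown here, three on one shared core have been measured in an assay on isolated protein for displacement of a labelled ligand from metabotropic glutamate receptor 5 (Homo sapiens), with a stated time of 60 min, tested at 1 uM; on this read-out lower numbers stand for less inhibition and higher numbers for more inhibition at the one concentration tested (going by the name of the read-out). Compound 3 stands second highest of the three: the step of a number 6 percentage points higher from compound 1 to compound 3 (within the scatter) is small, while a number 11 percentage points lower from compound 2 to compound 3 (beyond the scatter) is modest. Compound 4 `CC1CCN(c2c(S(=O)(=O)c3ccc(Cl)c(Cl)c3)cnc3ccc(F)cc23)CC1` differs from compound 3 by chloro in place of methoxy on an aromatic carbon, so the whole group reads 3-chloro-4-methoxyphenyl to 3,4-dichlorophenyl. For the measured compounds named here, no measured step swaps a methoxy for a chloro; only the two steps into compound 3 touch this ring, and one of them lies within the scatter. For compound 4 a step of a number 2 percentage points lower from compound 3 to compound 4 (within the scatter) in this assay is therefore expected, that is none beyond the scatter. Compound 4 is estimated at 80%, ranging from 65% to 93%.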

Compound 4, a percentage reported as inhibition, at one concentration (the size of the read-out at that concentration, not a potency): 91%
The estimate for compound 4 lay 11 percentage points below the measured number, and the stated range covers the measured number.
By their numbers in this assay, from the lowest: compounds 1, 3, 4 and 2 (each within the scatter of the next, the first and the last beyond it).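

Chloro in place of methoxy, ortho to a chloro group, gives a number 9 percentage points higher from compound 3 to compound 4 (within the scatter) and so shows no measurable loss when the methoxy goes. The 3,4-dichlorophenyl group gives a number 2 percentage points lower from compound 2 to compound 4 (within the scatter) and does not separate from 3-cyanophenyl, while a number 15 percentage points higher from compound 1 to compound 4 (beyond the scatter) sets it clear of 3-fluorophenyl, as 3-cyanophenyl also is. Nothing available explains these differences.

As far as these compounds go, whether an amine or a carboxylic acid on this aromatic carbon would keep the inhibition stays open. Readings at one concentration also leave the potency of these compounds unknown.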